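Trimming an aminophenyl down to an amino group

This account rests on a few compounds, and the source may have more. Where it says the series, first, only, none or still open, it means among the compounds named here.

Compound 1 `Cn1ccnc1Sc1cnc(-c2ccc(N)cc2)nc1-c1ccccc1O` was tested in an ADME assay on MDCK cells (Canis lupus familiaris) for cytotoxicity (on this read-out lower numbers stand for higher toxicity in this test and higher numbers for lower toxicity in this test), where compound 1 gave 80100 ug/mL. Two companions were measured alongside it: compound 2 `Cn1cnnc1Sc1cnc(C(C)(C)C)nc1-c1ccccc1O` gave 160000 ug/mL and compound 3 `Cc1ccc(O)c(-c2nc(C(C)(C)C)ncc2Sc2nccn2C)c1` gave 116000 ug/mL. All three numbers sit within the usual scatter of one another, so no ranking among them is warranted. Compound 4 `Cn1ccnc1Sc1cnc(N)nc1-c1ccccc1O` has not been measured. It differs from compound 1 in one place: amino in place of 4-aminophenyl on an aromatic carbon. Among the measured compounds shown here, no measured pair shows this change, so the step from compound 1 to compound 4 in this assay is expected to be small, with no clear direction beyond the scatter. On that basis compound 4 is estimated at 120000 ug/mL, in a range from 60000 ug/mL to 240000 ug/mL, which means a step of a 1.5-fold higher number from compound 1 to compound 4 (0.18 log units; within the scatter).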

Compound 4, half-maximal cytotoxic concentration: 388000 ug/mL
The estimate for compound 4 lay 3.2-fold (0.51 log units) below the measured number, and the stated range ends below it.
By their numbers in this assay, from the lowest: compounds 1, 3 and 2 (each within the scatter of the next); then compound 4.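

On the aromatic carbon between two ring nitrogen atoms, amino in place of 4-aminophenyl gives a 4.8-fold higher number from compound 1 to compound 4 (0.69 log units; beyond the scatter) in this assay, so this position does respond to the change. The two groups have the same counts of hydrogen-bond donors and acceptors and no net charge, but only 4-aminophenyl carries a six-membered aromatic ring of carbon only. Nothing at hand explains the step.

Going by these compounds, it remains open whether amino itself matters or any small group, such as methyl or hydroxyl, would do the same. Also open, on these data alone, is whether a plain phenyl would match 4-aminophenyl here.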